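Replacing 2-bromo-6-chlorophenyl in a series read at limits

A few compounds are considered here, and "the series" means these few. Any claim that something is new, unique, unknown or untested is made for them only; others in the source may bear on it.

In a physicochemical assay for solubility, in phosphate buffer, measured as kinetic solubility, at pH 7.4 (a higher number here means a more soluble compound, a lower number a less soluble compound), compound 1 `Cc1oc(-c2ccc(Cl)cc2)nc1CN1CCC(C(=O)NCCCN2C[C@H](C)C[C@H](C)C2)CC1` gives > 72 ug/mL, which is a limit. Compound 2 `Cc1oc(-c2c(F)cccc2F)nc1CN1CCC(C(=O)NCCCN2C[C@H](C)C[C@H](C)C2)CC1` gives > 72 ug/mL, also a limit. Compound 3 `Cc1oc(-c2c(Cl)cccc2Br)nc1CN1CCC(C(=O)NCCCN2C[C@H](C)C[C@H](C)C2)CC1` gives > 83 ug/mL, again a limit and not a number. Compound 4 `Cc1cccc(F)c1-c1nc(CN2CCC(C(=O)NCCCN3C[C@H](C)C[C@H](C)C3)CC2)c(C)o1` has 2-fluoro-6-methylphenyl in place of 2-bromo-6-chlorophenyl on an aromatic carbon. Within the data shown here, the steps that bear on this change the same group, and no size can be read from a step that the two limits leave unreadable from compound 1 to compound 2, a step that the two limits leave unreadable from compound 1 to compound 3 or a step that the two limits leave unreadable from compound 2 to compound 3, so no step beyond the scatter is expected in either direction. The expected step is an at least 1.1-fold lower number from compound 3 to compound 4 (0.06 log units; that floor lies within the scatter). For compound 4 the estimated value is 72 ug/mL, with an expected range of 60 ug/mL to 90 ug/mL.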

Compound 4, solubility: > 72 ug/mL
Compound 4 was reported as a limit; the forecaster's own chance of this, stated with the estimate: 90%; the middle value sits exactly at the limit.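

Among these compounds, compound 4, like compound 1, compound 2 and compound 3, is reported only as a limit in this assay, so no step to or from compound 4 can be read. The compounds shown leave open how far each true value lies from its limit, and so whether the four differ at all.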